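The compounds below may be only part of what the source reports. "The series", "measured", "known", "first", "only" and "open" are said of these compounds alone.

Measured compounds in a functional assay on NCI-H1975 cells (Homo sapiens) for antiproliferative activity, read by MTT assay, with a stated time of 72 h; on this read-out higher numbers stand for weaker inhibition and lower numbers for stronger inhibition:
compound 1, `COc1cc(N(C)CCN(C)C)c(NC(=O)c2ccnc(Cl)c2)cc1Nc1nccc(-c2cn(C)c3ccccc23)n1`, gives 2050 nM
compound 2, `COc1cc(N(C)CCN(C)C)c(NC(=O)c2cccnc2)cc1Nc1nccc(-c2cn(C)c3ccccc23)n1`, gives 1750 nM

Compound 2 has the lower of these two numbers, yet the step of a 1.2-fold lower number from compound 1 to compound 2 (0.07 log units; within the scatter) lies within the scatter, so the two compounds cannot be told apart. Compound 3, `COc1cc(N(C)CCN(C)C)c(NC(=O)c2cnccn2)cc1Nc1nccc(-c2cn(C)c3ccccc23)n1`, differs from compound 2 by pyrazin-2-yl in place of pyridin-3-yl on a carbonyl carbon. Within the data shown here, the only measured change at this carbonyl carbon, a 1.2-fold lower number from compound 1 to compound 2 (0.07 log units; within the scatter), produced no shift beyond the scatter, so no step beyond the scatter is expected here either, a 1.0-fold higher number from compound 2 to compound 3 (0.01 log units; within the scatter). Compound 3 is therefore estimated at 1800 nM, in a range from 700 nM to 4500 nM.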

Compound 3, half-maximal inhibitory concentration: 1220 nM
For compound 3 the middle estimate is 1.5-fold (0.17 log units) above the measured one, and the stated range covers the measured number.
By their numbers in this assay, from the lowest: compounds 3, 2 and 1 (each within the scatter of the next).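

Pyrazin-2-yl, with 2 hetero atoms in its ring where pyridin-3-yl has 1, leaves this carbonyl carbon's result within the scatter in this assay (a 1.4-fold lower number from compound 2 to compound 3 (0.16 log units; within the scatter)). The widest gap among the three compounds also stays within the scatter (a 1.7-fold lower number from compound 1 to compound 3 (0.23 log units; within the scatter)). So for these three aromatic rings, the extra ring nitrogen and the added hydrogen-bond acceptor bring no readable change.

From the compounds shown here alone, whether a plain phenyl ring or a saturated amine such as piperidin-4-yl at this place would move the number beyond the scatter remains open. No supporting measurement is available to explain these numbers.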